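A few compounds are considered here, and "the series" means these few. Any claim that something is new, unique, unknown or untested is made for them only; others in the source may bear on it.

Three compounds sharing one core were tested in a functional assay on the whole organism (strain Wistar) for inhibition, with Rattus norvegicus as the target, read by paw edema, with a stated time of 3 h, at a dose of 20 mg/kg by the oral route; a higher number here means more inhibition at the dose given (going by the name of the read-out), a lower number less inhibition. Compound 1 `COc1ccc(/C=C/C(=O)c2ccc3c(c2)CN(c2ccc(OC)cc2)CO3)cc1` gives 61.2% in this assay. Compound 2 `COc1ccc(N2COc3ccc(C(=O)/C=C/c4ccccc4O)cc3C2)cc1` gives 55.7% in this assay. Compound 3 `COc1ccc(/C=C/C(=O)c2ccc3c(c2)CN(c2ccc(C)cc2)CO3)cc1` gives 70.4% in this assay.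

Two single changes link these numbers. Compound 2 differs from compound 1 by 2-hydroxyphenyl in place of 4-methoxyphenyl on a double-bonded chain carbon bound to a double-bonded chain carbon, and this change gave a number 5.5 percentage points lower from compound 1 to compound 2 (within the scatter). Compound 3 differs from compound 1 by methyl in place of methoxy on an aromatic carbon, and this change gave a number 9.2 percentage points higher from compound 1 to compound 3 (within the scatter). Neither step is large enough to stand out from the usual scatter of this kind of measurement, and the values of compound 1 and compound 3 are too close to be ranked.

Compound 4 `Cc1ccc(N2COc3ccc(C(=O)/C=C/c4ccccc4O)cc3C2)cc1` has not yet been measured in this assay. It differs from compound 3 by 2-hydroxyphenyl in place of 4-methoxyphenyl on a double-bonded chain carbon bound to a double-bonded chain carbon. This is the same change that was made from compound 1 to compound 2, at the same place, so it occurs twice among these four compounds; the only thing that differs is the core it is made on, and the two cores differ as described for compound 3 against compound 1. For compound 4 the step from compound 3 is expected to be a number 5.4 percentage points lower from compound 3 to compound 4 (within the scatter) because the same change earlier gave a number 5.5 percentage points lower from compound 1 to compound 2 (within the scatter). Compound 4 is therefore estimated to give 65% in this assay, most likely between 52% and 76%.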

Compound 4, a percentage reported as inhibition, in the whole organism at one dose (the size of the read-out at that dose, not a potency): 51%
Compound 4: middle estimate off by 14 percentage points, on the high side, outside the stated range (below it).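

Putting 2-hydroxyphenyl in place of 4-methoxyphenyl on a double-bonded chain carbon bound to a double-bonded chain carbon gave a number 19.4 percentage points lower from compound 3 to compound 4 (beyond the scatter) in this assay, but this step cannot be told apart from the one seen on the core of compound 1: the same change on two cores in this assay, a number 5.5 percentage points lower (within the scatter) from compound 1 to compound 2 and a number 19.4 percentage points lower (beyond the scatter) from compound 3 to compound 4, 13.9 percentage points apart, within the scatter of two such steps. The other change, methyl in place of methoxy on an aromatic carbon, gave a number 4.7 percentage points lower from compound 2 to compound 4 (within the scatter), and its two readings cannot be told apart either: the same change on two cores in this assay, a number 9.2 percentage points higher (within the scatter) from compound 1 to compound 3 and a number 4.7 percentage points lower (within the scatter) from compound 2 to compound 4, 13.9 percentage points apart, within the scatter of two such steps. Nothing here therefore shows that the core alters the outcome of either change, but two pairs of compounds are too few to show that a step carries over at the same size, or that it would do so on any other core.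

The compounds shown leave open how the step would behave with other groups on that chain carbon, such as a phenyl ring bearing an amine or a carboxylic acid. They also leave open what other groups on the aromatic carbon would give in place of methyl or methoxy, such as chlorine or a longer chain.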